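The source may report more compounds than this note shows. Statements on the series, on what has been measured and on what is new or still open speak of the compounds shown alone.

Compound 1 `C[C@H](O)[C@H]1C(=O)N2C(C(=O)O)=C(C(C)(C)C)O[C@H]12` serves as the reference point of this small set. In an ADME assay, in phosphate buffer, at 28 degrees C, at pH 7.0 (a higher number here means that the compound lasts longer, a lower number that the compound disappears faster), compound 1 gives 7.1 h, the second highest of the three numbers in hand; its nearest neighbour is compound 3 `Cn1cc([C@H](O)[C@H]2C(=O)N3C(C(=O)O)=C(C(C)(C)C)O[C@H]23)nn1`, which gives 7 h, and the furthest is compound 2 `CC(C)(C)C1=C(C(=O)O)N2C(=O)[C@H]([C@@H](O)c3ccc(O)cc3)[C@H]2O1`, which gives 10.3 h. All three gaps sit within the scatter: a 1.0-fold lower number from compound 1 to compound 3 (0.01 log units; within the scatter), a 1.5-fold higher number from compound 1 to compound 2 (0.16 log units; within the scatter) and a 1.5-fold lower number from compound 2 to compound 3 (0.17 log units; within the scatter).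

Compound 4 `CC(C)(C)C1=C(C(=O)O)N2C(=O)[C@H]([C@@H](O)CCc3ccc(O)cc3)[C@H]2O1` differs from compound 1 by 4-hydroxybenzyl in place of hydrogen on a saturated chain carbon, two bonds along the chain from an oxygen on a saturated carbon and a saturated ring carbon. The measured step that bears most directly on this is the one placing 4-hydroxyphenyl on the chain carbon bound to the oxygen, a 1.5-fold higher number from compound 1 to compound 2 (0.16 log units; within the scatter); the step placing 1-methyl-1H-1,2,3-triazol-4-yl on that same carbon, a 1.0-fold lower number from compound 1 to compound 3 (0.01 log units; within the scatter), was flat. Both lie within the scatter, so no step beyond the scatter is expected here, with, if anything, a slight lean upward following compound 2. The expected step for compound 4 is therefore a 1.2-fold higher number from compound 1 to compound 4 (0.08 log units; within the scatter). Compound 4 is estimated at 8.5 h, in the range 5 h to 14 h.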

Compound 4, half-life: 21.2 h
For compound 4 the middle estimate is 2.5-fold (0.40 log units) below the measured one; the whole stated range lies below it.
By their numbers in this assay, from the lowest: compounds 3, 1 and 2 (each within the scatter of the next); then compound 4.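

In this assay this position now shows a change beyond the scatter: 4-hydroxybenzyl in place of hydrogen on the saturated chain carbon gives a 3.0-fold higher number from compound 1 to compound 4 (0.48 log units; beyond the scatter) and so marks this part of the side chain as one where the half-life can move. The earlier changes, on the chain carbon bound to the oxygen, gave a 1.5-fold higher number from compound 1 to compound 2 (0.16 log units; within the scatter) and a 1.0-fold lower number from compound 1 to compound 3 (0.01 log units; within the scatter) and so showed no such movement. Nothing measured here accounts for the rise.

From the compounds shown here alone, it stays open whether the step belongs to the aromatic ring, its hydroxyl or the added chain length. A plain benzyl group, or an amine or a carboxylic acid in place of the hydroxyl, would help separate these, and a longer chain would show whether the trend extends.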